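Urea analogues on a shared core: cytotoxicity in BJ cells

The source may hold more compounds than are shown below. What is called first, only, known or untested is meant among the compounds shown, and "the series" means these compounds.

This account concerns three ureas built on one core and a fourth that shares it. In an ADME assay on BJ cells (Homo sapiens) for cytotoxicity, with a stated time of 72 h (on this read-out lower numbers stand for an effect already at smaller amounts and higher numbers for an effect only at larger amounts of compound), compound 1, `Cc1cc(NC(=O)Nc2ncccc2C)c2ccccc2n1`, reaches only the limit of the assay, > 25000 nM, and not a number. Compound 2, `Cc1cc(NC(=O)Nc2ccc(F)c(F)c2)c2ccccc2n1`, likewise stops at the limit > 25000 nM in this assay. Compound 3, `COC(=O)c1cccc(NC(=O)Nc2cc(C)nc3ccccc23)c1`, gives 21000 nM in this assay. Compound 1 thus sits at the limit of > 25000 nM in this assay, at which 2 of the 3 values shown sit. No single-point step between measured compounds is shown. Compound 4, `Cc1cc(NC(=O)Nc2ccccc2N)c2ccccc2n1`, differs from compound 1 by 2-aminophenyl in place of 3-methylpyridin-2-yl on an amide-type nitrogen. With compound 1 at its limit, the expected step of a number no higher from compound 1 to compound 4 (the limit leaves the size open) is none beyond the scatter. Compound 4 is therefore estimated at 25000 nM in this assay, within 10000 nM to 60000 nM.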

Compound 4, half-maximal effective concentration: > 25000 nM
Compound 4 was reported as a limit; the forecaster's own chance of this, stated with the estimate: 70%; the middle value lies on the limit itself.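

For the compounds shown here, compound 1 and compound 4 both stop at a limit in this assay, so no step between them can be read. The compounds shown leave open how far either compound lies beyond that limit.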